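Chloro for methoxy on compound 1

This account rests on a few compounds, and the source may have more. Where it says the series, first, only, none or still open, it means among the compounds named here.

Measured so far:
Compound 1 `C/C=C/C(=O)N(Cc1ccc(OC)c(OC)c1)c1cc(OC)c(OC)c(OC)c1`: 39100 nM
Compound 2 `COc1cc(NCc2ccc(Br)cc2)cc(OC)c1OC`: > 80000 nM, a limit of the assay

Among the measured compounds shown here, in a functional assay on KYSE-450 cells (Homo sapiens) for inhibition, read by MTT assay, with a stated time of 48 h (on this read-out higher numbers stand for weaker inhibition and lower numbers for stronger inhibition), compound 1 gives 39100 nM, the only true number so far. The value of compound 2 is a limit and gives no number to compare with.

Compound 3 `C/C=C/C(=O)N(Cc1ccc(OC)c(Cl)c1)c1cc(OC)c(OC)c(OC)c1` differs from compound 1 by chloro in place of methoxy on an aromatic carbon, ortho to a methoxy group. For the measured compounds named here, no measured pair covers this change, so no step beyond the scatter is expected in this assay. The expected 1.3-fold lower number from compound 1 to compound 3 (0.12 log units; within the scatter) is small, leaning slightly towards stronger inhibition. For compound 3 the estimated value is 30000 nM, with an expected range of 12000 nM to 80000 nM.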

Compound 3, half-maximal inhibitory concentration: 10100 nM
Beside the measured number, compound 3's estimate is 3.0-fold (0.47 log units) above it; the measured number lies below the stated range.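

In this assay, chloro in place of methoxy, ortho to a methoxy group, gives a 3.9-fold lower number from compound 1 to compound 3 (0.59 log units; beyond the scatter). Among the compounds shown here, this is the first readable comparison, and it shows that this position does not need the methoxy group for inhibition and that a change here can move the read-out beyond the scatter. Compound 2 remains a limit and offers no comparison: the limit of > 80000 nM in this assay, at which 1 of the 3 values shown sits.

From the compounds shown here alone, whether the step belongs to chloro itself or to the loss of methoxy stays open. What a bare hydrogen, fluoro or trifluoromethyl would give at this position is also unknown.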